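A few compounds are considered here, and "the series" means these few. Any claim that something is new, unique, unknown or untested is made for them only; others in the source may bear on it.

Of the compounds shown here, three built on one shared core have been tested in an ADME assay on HEL cells (Homo sapiens) for cytotoxicity, with a stated time of 3 days; on this read-out higher numbers stand for lower toxicity in this test and lower numbers for higher toxicity in this test. Compound 1, `c1ccc(CCSCc2cnc3ccc(-c4ccccc4)cn23)cc1`, gives 4 ug/mL. Compound 2, `Cc1cc(-c2cccc([N+](=O)[O-])c2)c2ncc(CSCCc3ccccc3)n2c1`, gives 100 ug/mL. Compound 3, `COc1cccc(-c2cc(C)c3ncc(CSCCc4ccccc4)n3c2)c1`, gives 20 ug/mL, which places it second highest of the three: compound 2 shows a higher number and compound 1 a lower one, and both gaps lie beyond the usual scatter of this test. Compound 4, `Cc1cc(I)cn2c(CSCCc3ccccc3)cnc12`, differs from compound 3 in a single place: iodo in place of 3-methoxyphenyl on an aromatic carbon. Going by the values given here, no measured pair shows what such a swap does, so its direction is open. The expectation for compound 4 is a step of no change at the digits printed from compound 3 to compound 4 (within the scatter), not beyond the scatter, though with wide uncertainty. Compound 4 is therefore estimated at 20 ug/mL, within a range from 5 ug/mL to 100 ug/mL.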

Compound 4, minimum cytotoxic concentration: >= 0.8 ug/mL
Compound 4: only a limit was reported; the forecaster's own chance of this, stated with the estimate: 10%; the middle value is on the limit's open side.
By their numbers in this assay, from the lowest: compound 1; then compound 3; then compound 2.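

Going by these compounds alone, for compound 4 the assay gave only a limit, not a number, so no step from compound 3 to compound 4 can be read: the limit of >= 0.8 ug/mL in this assay, at which 1 of the 4 values shown sits. The compounds shown leave open whether iodo in place of 3-methoxyphenyl raises, lowers or leaves unchanged the number.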